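The compounds below may be only part of what the source reports. "The series", "measured", "known", "first", "only" and "open" are said of these compounds alone.

Compound 3 `COc1cccc(C(Nc2ccccn2)c2ccc3cccnc3c2O)c1` gives the highest number of the three measured compounds in an assay for inhibition of protein disulfide-isomerase (Homo sapiens), with a stated time of 1 h (a lower number here means a stronger inhibitor, a higher number a weaker inhibitor), with a value of 2860 nM. Compound 1 `Oc1c(C(Nc2ccccn2)c2ccccc2Cl)ccc2cccnc12` gives 500 nM in this assay, and compound 2 `Oc1cccc(C(Nc2ccccn2)c2ccc3cccnc3c2O)c1Cl` gives 370 nM; the step of a 1.4-fold lower number from compound 1 to compound 2 (0.13 log units; within the scatter) separates those two. The two steps that lead to compound 3 are a 5.7-fold higher number from compound 1 to compound 3 (0.76 log units; beyond the scatter) and a 7.7-fold higher number from compound 2 to compound 3 (0.89 log units; beyond the scatter), so in both cases replacing a chlorine-bearing phenyl group by a 3-methoxyphenyl group went with a weaker inhibitor.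

Compound 4 `Oc1c(C(Nc2ccccn2)c2ccc(Cl)cc2)ccc2cccnc12` has not yet been measured. The change from compound 3 is 4-chlorophenyl in place of 3-methoxyphenyl on a saturated chain carbon bound to an aromatic carbon and a nitrogen on an aromatic ring. Among the measured compounds shown here, no measured step swaps a 3-methoxyphenyl directly for a 4-chlorophenyl. The closest guide is the step of a 5.7-fold higher number from compound 1 to compound 3 (0.76 log units; beyond the scatter), where a 2-chlorophenyl compound was the stronger inhibitor, and the step of a 7.7-fold higher number from compound 2 to compound 3 (0.89 log units; beyond the scatter), which points the same way. Compound 4 carries its chlorine at a different ring position than compound 1 or compound 2, so the size of the return is uncertain, but a drop in the number is expected rather than a rise. The expected step is a 3.2-fold lower number from compound 3 to compound 4 (0.50 log units; beyond the scatter). The estimated value for compound 4 in this assay is 900 nM, with a likely range from 350 nM to 2500 nM.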

Compound 4, half-maximal inhibitory concentration: 170 nM
For compound 4 the middle estimate is 5.3-fold (0.72 log units) above the measured one, outside the stated range (below it).
By their numbers in this assay, from the lowest: compound 4; then compounds 2 and 1 (each within the scatter of the next); then compound 3.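

In this assay, among the compounds shown here, the choice of phenyl group on this saturated chain carbon matters more than the earlier compounds showed, with a 17-fold lower number from compound 3 to compound 4 (1.23 log units; beyond the scatter) as the largest step in the set. The position of the chlorine also counts, since 4-chlorophenyl in place of 2-chlorophenyl gives a 2.9-fold lower number from compound 1 to compound 4 (0.47 log units; beyond the scatter) and the comparison with the hydroxy-bearing ring gives a 2.2-fold lower number from compound 2 to compound 4 (0.34 log units; beyond the scatter) in the same direction, which makes compound 4 the strongest inhibitor of the four. The data give no measured reason why this change has such an effect.

The step between the 3-methoxyphenyl and 4-chlorophenyl compounds changes both the group and its place on the ring, so 3-chlorophenyl and 4-methoxyphenyl analogues would be needed to tell those two changes apart. It also remains open whether chlorine itself is needed at this place or whether another group on the phenyl ring, such as fluorine, methyl or an amine, would give a similar number, and every compound shown keeps the same shared core.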